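From Bromo to Methoxy: What Compound 3 Might Show

This account rests on a few compounds, and the source may have more. Where it says the series, first, only, none or still open, it means among the compounds named here.

Compound 2 `C=CC(=O)Nc1cccc(NC(=O)CSc2nc(Nc3cccc(Br)c3)c3ccccc3n2)c1` gives 15000 nM in a functional assay on PC-3 cells (Homo sapiens) for inhibition, read by MTT assay, with a stated time of 72 h; on this read-out higher numbers stand for weaker inhibition and lower numbers for stronger inhibition. Its only measured neighbour is compound 1 `C=CC(=O)Nc1cccc(NC(=O)CSc2nc(Nc3ccccc3C)c3ccccc3n2)c1`, which in this assay gives 23200 nM; the step of a 1.5-fold lower number from compound 1 to compound 2 (0.19 log units; within the scatter) lies within the scatter, so the two compounds cannot be told apart on the numbers shown. Compound 3 `C=CC(=O)Nc1cccc(NC(=O)CSc2nc(Nc3cccc(OC)c3)c3ccccc3n2)c1` differs from compound 2 by methoxy in place of bromo on an aromatic carbon. Within the data shown here, the single measured step concerns a different exchange of groups on that same aromatic ring and bears only loosely on the present change; it showed that such an exchange moved the number little. Among the measured compounds shown here, no measured step shows what methoxy in place of bromo does here. The expectation for compound 3 is therefore no movement beyond the scatter, a step of a 1.2-fold higher number from compound 2 to compound 3 (0.08 log units; within the scatter). The estimate for compound 3 in this assay is 18000 nM, with a range from 8000 nM to 45000 nM.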

Compound 3, half-maximal inhibitory concentration: 34900 nM
For compound 3 the middle estimate is 1.9-fold (0.29 log units) below the measured one; the measured number falls inside the stated range.
By their numbers in this assay, from the lowest: compounds 2, 1 and 3 (each within the scatter of the next, the first and the last beyond it).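

In this assay, methoxy in place of bromo gives a 2.3-fold higher number from compound 2 to compound 3 (0.37 log units; beyond the scatter) and so provides the only step shown that lies beyond the scatter, which means that a change on this aromatic carbon, meta to a large group, can move the number, if only modestly. The other new step, a 1.5-fold higher number from compound 1 to compound 3 (0.18 log units; within the scatter), does not separate the 3-methoxyphenyl and 2-methylphenyl groups on that nitrogen, so the difference appears only against the 3-bromophenyl group of compound 2. No measurement shown here offers an explanation for this modest step.

From the compounds shown here alone, it remains open whether an amine, a carboxylic acid or a longer chain such as ethoxy at this same place would move the number further in either direction. The compounds shown also leave open whether methoxy in place of bromo would give a similar step elsewhere on this ring.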